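Urea aryl swap: from dichlorophenyl to a single trifluoromethylphenyl

A few compounds are considered here, and "the series" means these few. Any claim that something is new, unique, unknown or untested is made for them only; others in the source may bear on it.

Compound 3, `COc1cc(Cl)cc(-c2nn(-c3cccc(NC(=O)Nc4ccc(Cl)c(Cl)c4)c3)cc2-c2ccncc2)c1`, gives 87% in a functional assay on SF-295 cells (Homo sapiens) for inhibition, read by sulforhodamine B assay, with a stated time of 48 h, tested at 0.01 uM (on this read-out higher numbers stand for a weaker effect at the one concentration tested and lower numbers for a stronger effect), the second highest of the three numbers shown. Compound 2, `COc1cc(Cl)cc(-c2nn(-c3cccc(NC(=O)Nc4cc(C(F)(F)F)cc(C(F)(F)F)c4)c3)cc2-c2ccncc2)c1`, gives 95% in this assay, within the scatter of compound 3. Among the measured compounds shown here, compound 1, `COc1cc(Cl)cc(-c2nn(-c3cccc(NC(=O)Nc4ccc(Cl)c(C(F)(F)F)c4)c3)cc2-c2ccncc2)c1`, gives 59%, and the only step on record, a number 28 percentage points higher from compound 1 to compound 3 (beyond the scatter), is beyond the scatter. Compound 4, `COc1cc(Cl)cc(-c2nn(-c3cccc(NC(=O)Nc4cccc(C(F)(F)F)c4)c3)cc2-c2ccncc2)c1`, differs from compound 3 by 3-(trifluoromethyl)phenyl in place of 3,4-dichlorophenyl on an amide-type nitrogen. This change runs partly against that step: a trifluoromethyl comes back in while chlorine leaves, though without the further substituent carried by compound 1. A drop toward the number of compound 1 is therefore expected, smaller than the full step because compound 1 gives 59% with a further chlorine that compound 4 does not carry; the expected step is a number 15 percentage points lower from compound 3 to compound 4 (beyond the scatter). Compound 4 is estimated at 72%, between 50% and 95%.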

Compound 4, a percentage reported as activity, at one concentration (the size of the read-out at that concentration, not a potency): 94%
Compound 4: middle estimate off by 22 percentage points, on the low side; the range from low to high includes it.
By their numbers in this assay, from the lowest: compound 1; then compounds 3, 4 and 2 (each within the scatter of the next).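

In this assay the step of a number 7 percentage points higher from compound 3 to compound 4 (within the scatter) shows that 3-(trifluoromethyl)phenyl and 3,4-dichlorophenyl on the amide-type nitrogen cannot be told apart here, and the step of a number 1 percentage points lower from compound 2 to compound 4 (within the scatter) shows the same for hydrogen in place of trifluoromethyl. Hydrogen in place of chloro, by contrast, gives a number 35 percentage points higher from compound 1 to compound 4 (beyond the scatter) on this read-out, so a single trifluoromethyl does not reproduce the lower number of compound 1, which also carries the chloro. Going by these compounds, whether a single chloro, an amine or a carboxylic acid on that phenyl would give a number like that of compound 1 stays open. Nothing measured here accounts for this difference.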